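Swapping the Amino Chain for a Sulfanyl Chain

The source may report more compounds than this note shows. Statements on the series, on what has been measured and on what is new or still open speak of the compounds shown alone.

Measured in an in vitro ADME assay on microsomes (Homo sapiens) for metabolic stability; a lower number here means that the compound disappears faster, a higher number that the compound lasts longer
- compound 1 `CCC(CC)Nc1nc(OC)c(-c2ccc(Cl)cc2Cl)nc1C` gives 0.933 h
- compound 2 `CCc1nc(-c2ccc(Cl)cc2Cl)c(CC)nc1NC(COC)COC` gives 0.15 h
- compound 3 `CCc1nc(-c2ccc(OC)cc2O)c(CC)nc1NC(CC)CC` gives 0.3 h

Among these three, compound 2 at 0.15 h sits level, within the usual scatter, with compound 3 at 0.3 h in this assay. Compound 1 at 0.933 h stands higher than compound 2, and that gap lies beyond the scatter.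

The next compound to be tested is compound 4 `CCc1nc(-c2ccc(Cl)cc2Cl)c(CC)nc1SC(C)CC`, which keeps the rest of compound 2 and changes one group on an aromatic carbon, with (sec-butyl)sulfanyl in place of (2-methoxy-1-(methoxymethyl)ethyl)amino ((sec-butyl)sulfanyl in place of (2-methoxy-1-(methoxymethyl)ethyl)amino on an aromatic carbon). Within the data shown here, no measured pair differs in only one place, so the size of this step cannot be read from the data directly. Like compound 2, compound 3 carries two ethyl groups and gives 0.3 h, and the expectation leans on that value. A modest upward move that stays within the scatter is expected, the estimated step being a 1.7-fold higher number from compound 2 to compound 4 (0.22 log units; within the scatter). For compound 4 the estimated half-life is 0.25 h, with an expected range from 0.1 h to 0.6 h.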

Compound 4, half-life: 0.283 h
Beside the measured number, compound 4's estimate is 1.1-fold (0.05 log units) below it; the measured number falls inside the stated range.
By their numbers in this assay, from the lowest: compounds 2, 4 and 3 (each within the scatter of the next); then compound 1.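

In this assay, among these compounds, this is the first step at this position that can be read from a single change, a 1.9-fold higher number from compound 2 to compound 4 (0.28 log units; within the scatter), and it sets the two compounds level. At this aromatic carbon, para to a 2,4-dichlorophenyl group, a chain of 8 heavy atoms with 1 hydrogen-bond donor and 3 hydrogen-bond acceptors gives way to a chain of 5 heavy atoms with 0 hydrogen-bond donors and 1 hydrogen-bond acceptor, and a sulfur replaces the nitrogen that joined the chain to the ring, with no change in half-life that stands clear of the scatter. No measurement at hand accounts for this outcome.

The single step changes the joining atom and the chain together, so the compounds shown do not separate the two, and compound 1 and compound 3 differ from this pair in more than one place, so steps to them cannot be read. On these data alone, how a (sec-butyl)amino chain, a (sec-butyl)oxy chain or a sulfonyl link at this position would stand in this assay remains open.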